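The compounds below may be only part of what the source reports. "The series", "measured", "known", "first", "only" and "open" are said of these compounds alone.

Going by the values given here, compound 1 `C[C@H]1CC[C@@H]2[C@@H](OC(=O)[C@]23CC(c2c(Cl)cccc2Cl)=NO3)[C@]2(C)C(=O)C=C[C@@]12O` gives 56000 nM in a functional assay on PC-3 cells (Homo sapiens) for cytotoxicity, read by sulforhodamine B assay, with a stated time of 48 h (a higher number here means a weaker inhibitor, a lower number a stronger inhibitor), the second highest of the three numbers so far; its nearest neighbour is compound 3 `Cc1cccc(C2=NO[C@]3(C2)C(=O)O[C@@H]2[C@H]3CC[C@H](C)[C@]3(O)C=CC(=O)[C@@]23C)c1`, which gives 66600 nM, and the furthest is compound 2 `C[C@H]1CC[C@@H]2[C@@H](OC(=O)[C@]23CC(c2ccc(O)cc2)=NO3)[C@]2(C)C(=O)C=C[C@@]12O`, which gives 20000 nM. Compound 4 `C[C@H]1CC[C@@H]2[C@@H](OC(=O)[C@]23CC(c2ccc(C#N)cc2)=NO3)[C@]2(C)C(=O)C=C[C@@]12O` awaits measurement and differs from compound 1 in one place: 4-cyanophenyl in place of 2,6-dichlorophenyl on a carbon with a double bond to nitrogen. Among the compounds with values here, two measured steps bear on this exchange, both replacing the same 2,6-dichlorophenyl: a 2.8-fold lower number from compound 1 to compound 2 (0.45 log units; beyond the scatter), whereas a 1.2-fold higher number from compound 1 to compound 3 (0.08 log units; within the scatter). The incoming 4-cyanophenyl, like the 4-hydroxyphenyl, brings one hydrogen-bond acceptor, so a modest step to a lower number in this assay is expected rather than none. The expected step is a 1.6-fold lower number from compound 1 to compound 4 (0.20 log units; within the scatter). Compound 4 is estimated at 35000 nM, within a range from 15000 nM to 80000 nM.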

Compound 4, half-maximal inhibitory concentration: 32000 nM
The estimate for compound 4 lay 1.1-fold (0.04 log units) above the measured number; the range from low to high includes it.
By their numbers in this assay, from the lowest: compounds 2, 4, 1 and 3 (each within the scatter of the next, the first and the last beyond it).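

In this assay, 4-cyanophenyl on the carbon with a double bond to nitrogen cannot be told apart from 2,6-dichlorophenyl (a 1.8-fold lower number from compound 1 to compound 4 (0.24 log units; within the scatter)), but it does separate from 3-methylphenyl (a 2.1-fold lower number from compound 3 to compound 4 (0.32 log units; beyond the scatter)). Cyano in place of hydroxy on the aromatic carbon also stays within the scatter (a 1.6-fold higher number from compound 2 to compound 4 (0.20 log units; within the scatter)), so compound 4, with no hydrogen-bond donor in its new group, cannot be told apart from compound 2. No measurement here explains these differences.

As far as these compounds go, whether a 4-aminophenyl or 4-carboxyphenyl group would move the number further at this position remains open.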